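The source may hold more compounds than are shown below. What is called first, only, known or untested is meant among the compounds shown, and "the series" means these compounds.

Measured so far in an ADME assay on HEK293 cells (Homo sapiens) for cytotoxicity, with a stated time of 72 h; on this read-out higher numbers stand for an effect only at larger amounts of compound and lower numbers for an effect already at smaller amounts:

- compound 1 `Cc1cc(NC(=O)Nc2ccc(C)c(Cl)c2)c2ccccc2n1`: > 25000 nM, a limit of the assay rather than a number
- compound 2 `Cc1cc(NC(=O)Nc2cc(F)ccc2F)c2ccccc2n1`: 12000 nM
- compound 3 `Cc1cc(NC(=O)Nc2ccc(N)cc2)c2ccccc2n1`: > 25000 nM, again a limit of the assay

Compound 2 is the only one of the three with a measured number in this assay; the other two are limits, (the limit of > 25000 nM in this assay, at which 2 of the 3 values shown sit). Within the data shown here, no step between two measured compounds is available here, so nothing can be said about how a single change shifts the read-out.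

Compound 4 `Cc1cc(NC(=O)Nc2ccccc2F)c2ccccc2n1` has not yet been measured. It differs from compound 2 by hydrogen in place of fluoro on an aromatic carbon. Among the measured compounds shown here, with no measured step to draw on, the expectation is a step from compound 2 to compound 4 of a 1.3-fold higher number from compound 2 to compound 4 (0.10 log units; within the scatter), that is, no change beyond the usual scatter. Compound 4 is therefore estimated at 15000 nM, within a range from 6000 nM to 40000 nM, in this assay.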

Compound 4, half-maximal effective concentration: > 25000 nM
Compound 4 was reported as a limit; the forecaster's own chance of this, stated with the estimate: 40%; at least 1.6-fold (0.22 log units) between middle value and limit.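

In this assay, hydrogen in place of the fluoro group that sits meta to a large group and para to a fluoro group gives an at least 2.0-fold higher number from compound 2 to compound 4 (0.31 log units; beyond the scatter). This is the first single change shown to move the read-out beyond the scatter, but the step is only a minimum, as the value of compound 4 is a limit and not a number. The step between compound 3 and compound 4 cannot be read, as both values are limits.

On these data alone, whether a chloro or methoxy group on this same carbon would give a number like that of compound 2 stays open. Most of the values give no exact number: the limit of > 25000 nM in this assay, at which 3 of the 4 values shown sit.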